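The source may hold more compounds than are shown below. What is called first, only, known or untested is meant among the compounds shown, and "the series" means these compounds.

Compounds measured in an assay on isolated protein for inhibition of histone deacetylase 8 (Homo sapiens), with a stated time of 1 h; on this read-out higher numbers stand for weaker inhibition and lower numbers for stronger inhibition:
compound 1 `Cc1ccc(NC(=O)COc2ccc3cc(/C=C4/SC(=O)NC4=O)ccc3c2)cc1` gives 9000 nM;
compound 2 `O=C(COc1ccc2cc(/C=C3/SC(=O)NC3=O)ccc2c1)Nc1ccc(F)cc1` gives 6600 nM.

Compound 2 has the lower of the two numbers, though the step of a 1.4-fold lower number from compound 1 to compound 2 (0.13 log units; within the scatter) lies within the scatter, so the two cannot be ordered. Compound 3 `O=C(COc1ccc2cc(/C=C3/SC(=O)NC3=O)ccc2c1)Nc1cc(Cl)cc(C(F)(F)F)c1` differs from compound 2 by 3-chloro-5-(trifluoromethyl)phenyl in place of 4-fluorophenyl on an amide-type nitrogen. Among the measured compounds shown here, the only step that bears on a change at this amide-type nitrogen is a 1.4-fold lower number from compound 1 to compound 2 (0.13 log units; within the scatter), a small one, so no step beyond the scatter is expected for compound 3 in this assay, in either direction. Compound 3 is therefore estimated at 5500 nM, within 1800 nM to 17000 nM, a step of a 1.2-fold lower number from compound 2 to compound 3 (0.08 log units; within the scatter).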

Compound 3, half-maximal inhibitory concentration: > 50000 nM
Compound 3 ended at the assay's limit; the forecaster's own chance of this, stated with the estimate: 5%; at least 9.0-fold (0.95 log units) between middle value and limit.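

Unlike the earlier change at this amide-type nitrogen, 3-chloro-5-(trifluoromethyl)phenyl in place of 4-fluorophenyl gives a step beyond the scatter towards weaker inhibition, with an at least 7.5-fold higher number from compound 2 to compound 3 (0.87 log units; beyond the scatter) in this assay. The change from 4-methylphenyl points the same way, with an at least 5.5-fold higher number from compound 1 to compound 3 (0.74 log units; beyond the scatter) on the same read-out. Compound 3 gives > 50000 nM, which is a limit of the assay and not a number, so both steps give only a minimum size: the limit of > 50000 nM in this assay, at which 1 of the 3 values shown sits.

On these data alone, whether the chloro or the trifluoromethyl group alone would give such a step remains open. So does the effect of an amine or a carboxylic acid on this phenyl ring.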